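The compounds below may be only part of what the source reports. "The series", "measured", "known", "first", "only" and "open" are said of these compounds alone.

Series notes. Compound 1 `CC(C)N(Cc1cccc(OCCCCCC(=O)O)c1)C(=O)c1ccc(-c2cccc(O)c2)cc1` and compound 2 `CCOC(=O)CCCCCOc1cccc(CN(C(=O)c2ccc(-c3cccnc3)cc2)C(C)C)c1` share one core and differ only in the group carried on that core. In an ADME assay on Raji cells (Homo sapiens) for cytotoxicity, read by CellTiter-Glo and resazurin assay, with a stated time of 72 h (on this read-out higher numbers stand for an effect only at larger amounts of compound and lower numbers for an effect already at smaller amounts), compound 1 gives > 26000 nM, which is a limit of the assay and not a number. In this assay compound 2 gives > 26000 nM, likewise a limit. Compound 2 therefore stands at the same point as every other measured value here, as the limit of > 26000 nM in this assay, at which 2 of the 2 values shown sit, records; no number separates the two. Compound 3 `CCOC(=O)CCCCCOc1cccc(CN(C(=O)c2ccc(-c3cccc(C(F)(F)F)c3)cc2)C(C)C)c1` has not yet been measured. From compound 2 to compound 3 the change is 3-(trifluoromethyl)phenyl in place of pyridin-3-yl on an aromatic carbon. Going by the values given here, no step between measured compounds is available, so the series gives no size for this change. The step that the limit leaves unreadable from compound 2 to compound 3 is expected to be none beyond the scatter. Compound 3 is estimated at about 30000 nM, within 12000 nM to 100000 nM, most probably again reported only as a limit.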

Compound 3, half-maximal effective concentration: > 26000 nM
Compound 3 was reported as a limit; the forecaster's own chance of this, stated with the estimate: 80%; the middle value is on the limit's open side.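

No step can be read from compound 2 to compound 3 in this assay, as both values are limits and not numbers, and all compounds shown stand at one point: the limit of > 26000 nM in this assay, at which 3 of the 3 values shown sit.

The compounds shown leave open what size, if any, the change from pyridin-3-yl to 3-(trifluoromethyl)phenyl has in this assay.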